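Changing the Aryl Ether: From Compound 2 to Compound 3

A few compounds are considered here, and "the series" means these few. Any claim that something is new, unique, unknown or untested is made for them only; others in the source may bear on it.

compound 1 `CCc1nn(C)c(CO/N=C/c2c(C)nn(C)c2Oc2ccc(Cl)cc2)c1Cl`: < 80%
compound 2 `CCc1nn(C)c(CO/N=C/c2c(C)nn(C)c2Oc2cccc(C)c2)c1Cl`: < 80%

In a functional assay on SMMC-7721 cells (Homo sapiens) for inhibition, read by MTT assay, with a stated time of 72 h, tested at 25 uM (a higher number here means more inhibition at the concentration tested (going by the name of the read-out), a lower number less inhibition), compound 1 gives < 80%, which is a limit of the assay and not a number. Compound 2 gives < 80%, likewise a limit. Compound 2 thus stands at the limit of < 80% in this assay, at which 2 of the 2 values shown sit. The step that the two limits leave unreadable from compound 1 to compound 2 cannot be read from these two limits. Compound 3 `CCc1nn(C)c(CO/N=C/c2c(C)nn(C)c2Oc2ccccc2OC)c1Cl` differs from compound 2 by 2-methoxyphenyl in place of 3-methylphenyl on an oxygen on an aromatic ring. Among the compounds with values here, the only measured step touches the same place but yields no readable size, so no step beyond the scatter is expected here. The expected step is a step that the limit leaves unreadable from compound 2 to compound 3. For compound 3 the estimate is 35%, ranging from 5% to 78%.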

Compound 3, a percentage reported as inhibition, at one concentration (the size of the read-out at that concentration, not a potency): < 80%
Compound 3 was reported as a limit (the forecaster's own chance of this, stated with the estimate: 0.85%); the middle value is on the limit's open side.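

No step can be read between compound 1, compound 2 and compound 3, because all their results in this assay are limits and not numbers: the limit of < 80% in this assay, at which 3 of the 3 values shown sit. The compounds shown leave open how much inhibition each of these three groups on the oxygen actually gives.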